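A Single Fluorine Added to Compound 1

This account rests on a few compounds, and the source may have more. Where it says the series, first, only, none or still open, it means among the compounds named here.

Measured compounds:
compound 1 `Cn1c(CN2CCC(c3ccccc3)CC2)nc2ccccc21` — 6310 nM
compound 2 `Cn1c(CN2CCN(c3ccccc3C(F)(F)F)CC2)nc2ccccc21` — > 15800 nM

Of the compounds shown here, two sharing the same core have been measured in a functional assay on CHO cells for agonist activity at metabotropic glutamate receptor 2 (Homo sapiens), read by FLIPR; a higher number here means that more compound is needed for the effect, a lower number that less compound is needed. Compound 1 `Cn1c(CN2CCC(c3ccccc3)CC2)nc2ccccc21` is the only one of the two for which a number has been obtained: in this assay compound 1 gives 6310 nM. Compound 2 `Cn1c(CN2CCN(c3ccccc3C(F)(F)F)CC2)nc2ccccc21` reaches only a limit of the assay, and in this assay compound 2 gives > 15800 nM. Among the compounds with values here, compound 1 therefore stands as the sole real number in this small set, with the other entry being a limit (the limit of > 15800 nM in this assay, at which 1 of the 2 values shown sits).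

Compound 3 `Cn1c(CN2CCC(c3ccccc3F)CC2)nc2ccccc21` has not yet been measured. It differs from compound 1 in one place: fluoro in place of hydrogen on an aromatic carbon. Within the data shown here, no pair of measured compounds shows what this change does, so the expected step rests on the structural change alone. In this assay the writer expects a step from compound 1 to compound 3 of a 1.3-fold lower number from compound 1 to compound 3 (0.10 log units; within the scatter), that is, no change beyond the usual scatter in either direction. Compound 3 is accordingly estimated at 5000 nM, within a range from 1500 nM to 16000 nM.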

Compound 3, half-maximal effective concentration: 3980 nM
Compound 3: the middle estimate sits 1.3-fold (0.10 log units) above what was measured, and the stated range covers the measured number.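

Within the data shown here, with compound 3, this assay gives for the first time a pair of measured compounds that differ in one place, and the change from phenyl to 2-fluorophenyl comes out as a 1.6-fold lower number from compound 1 to compound 3 (0.20 log units; within the scatter) on this reading. A fluoro on an aromatic carbon, ortho to a large group, therefore leaves the result indistinguishable from that of the unsubstituted phenyl ring, so this position accepts this one heavy atom with no step beyond the scatter. Nothing among the measurements shown offers a cause for this outcome, and the one limit among the values has no bearing on this single change.

The compounds shown leave open whether this position would respond in the same way to a larger or different group, such as chloro, methoxy, trifluoromethyl or an amine, since fluoro is the only replacement for hydrogen seen here. They also leave open whether fluoro on any other carbon of the phenyl ring would give a step beyond the scatter, and whether two or more fluoro groups on that ring would do so.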